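The source may hold more compounds than are shown below. What is called first, only, known or untested is meant among the compounds shown, and "the series" means these compounds.

Working notes on the series. In a functional assay on DU-145 cells (Homo sapiens) for antiproliferative activity, read by WST assay, with a stated time of 72 h (a lower number here means that less compound is needed, a higher number that more compound is needed for the effect), compound 2 (`CCCCCCCC/C=C\c1c(C)c(/C=C/CCCCCCCC)c(C)[n+]2c1CCC2`) gives 0.8 uM and compound 1 (`CCCCCCCC/C=C\c1c(C)c(/C=C\CCCCCCCC)c2[n+](c1C)CCC2`) gives 1 uM, two values within the scatter of each other. Compound 3 (`CCCCCCCC/C=C\c1c(C)cc(C)[n+]2c1CCC2`) gives 0.2 uM. Compound 2 thus sits with compound 1 at the upper end of the three numbers, and the gap to the lowest is a 4.0-fold lower number from compound 2 to compound 3 (0.60 log units; beyond the scatter).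

The unmeasured compound 4 (`CCCCCCCC/C=C\c1c(C)c(/C=C/CCCCCCCC)c2[n+](c1C)CCC2`) differs from compound 2 as follows: the two compounds have the same atoms and bonds and differ only in configuration as drawn: 2 of 2 stereo elements differ; a double bond is drawn E in compound 2 and Z in compound 4; a double bond is drawn Z in compound 2 and E in compound 4. Nothing leaves and nothing enters.

Going by the values given here, the one measured step of this kind is a 1.3-fold lower number from compound 1 to compound 2 (0.10 log units; within the scatter), and it rests on (the fact that compounds 1 and 2 differ only in the configuration as drawn). That step changed one of the two stereo elements, whereas the present change touches both, so it covers only part of the change. How two such changes combine has not been measured. The larger steps, a 5.0-fold lower number from compound 1 to compound 3 (0.70 log units; beyond the scatter) and a 4.0-fold lower number from compound 2 to compound 3 (0.60 log units; beyond the scatter), replace a whole chain with hydrogen and do not bear on a change of configuration. No step beyond the scatter is therefore expected in this assay. The expected step is a 1.1-fold higher number from compound 2 to compound 4 (0.05 log units; within the scatter). Compound 4 is estimated at 0.9 uM, with an expected range from 0.4 uM to 2 uM.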

Compound 4, concentration for half-maximal effect: 0.2 uM
Compound 4: middle estimate off by 4.5-fold (0.65 log units), on the high side; the measured number lies below the stated range.
By their numbers in this assay, from the lowest: compounds 3 and 4 (each within the scatter of the next); then compounds 2 and 1 (each within the scatter of the next).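

Configuration alone is enough to move the number in this assay: a 4.0-fold lower number from compound 2 to compound 4 (0.60 log units; beyond the scatter), and a 5.0-fold lower number from compound 1 to compound 4 (0.70 log units; beyond the scatter), with no atom or bond changed in either pair, so the gap can be traced only to the double-bond geometry: the fact that compounds 2 and 4 differ only in the configuration as drawn

Compound 2 and compound 4 each differ from compound 1 in one stereo element but from each other in both, so the two steps from compound 1 concern different double bonds, and they do not match: a 1.3-fold lower number from compound 1 to compound 2 (0.10 log units; within the scatter), whereas the change leading to compound 4 goes beyond the scatter. The earlier single step therefore described one double bond only, and the result shows that the two double bonds of this series cannot be treated as interchangeable in this assay.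

The compounds shown leave open how the remaining combination of the two double-bond geometries would stand in this assay, and whether the same dependence on geometry holds for the saturated decyl chain or a longer chain in place of dec-1-en-1-yl. They also leave open whether a chain ending in an amine or a carboxylic acid would keep this difference between the isomers.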